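The compounds below may be only part of what the source reports. "The series", "measured", "known", "first", "only" and "open" are said of these compounds alone.

Measured compounds in a functional assay on A549 cells (Homo sapiens) for inhibition, read by sulforhodamine B assay, with a stated time of 48 h; on this read-out higher numbers stand for weaker inhibition of growth and lower numbers for stronger inhibition of growth:
compound 1 `COc1cc(-c2nn(-c3cccc(NC(=O)c4ccc(Cl)c(C(F)(F)F)c4)c3)cc2-c2ccncc2)ccc1Cl` – > 32500 nM
compound 2 `O=C(Nc1cccc(-n2cc(-c3ccncc3)c(-c3ccc(Cl)c(O)c3)n2)c1)Nc1cc(C(F)(F)F)cc(C(F)(F)F)c1` – 1690 nM
compound 3 `COc1cc(-c2nn(-c3cccc(NC(=O)Nc4cccc(C(F)(F)F)c4)c3)cc2-c2ccncc2)ccc1Cl` – > 50000 nM

Compound 1 gives only a limit in this assay, > 32500 nM, so its true value is not known. Compound 3 likewise returns only a limit, > 50000 nM. Going by the values given here, the one step that joins two measured compounds in one place, a step that the two limits leave unreadable from compound 1 to compound 3, is therefore unreadable; the two limits are recorded as the limit of > 32500 nM in this assay, at which 1 of the 3 values shown sits, and (the limit of > 50000 nM in this assay, at which 1 of the 3 values shown sits). Among the compounds with values here, compound 2, which differs from the others in two places, is the only compound with a number, 1690 nM.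

Compound 4 `COc1cc(-c2nn(-c3cccc(NC(=O)Nc4ccc(Cl)c(C(F)(F)F)c4)c3)cc2-c2ccncc2)ccc1Cl` arises from compound 1 by (4-chloro-3-(trifluoromethyl)phenyl)amino in place of 4-chloro-3-(trifluoromethyl)phenyl on a carbonyl carbon. Within the data shown here, no measured step bears directly on this change: the only step from compound 1 ends at a limit, and compound 3 with its related amino group is also a limit. Compound 2 shows that a urea built on a closely related core can reach a measurable value, but it carries a different aryl group and a different core. The expectation for compound 4 is therefore weak growth inhibition, with wide uncertainty, and a fair chance that this assay again reports only a limit. The step of an at least 1.6-fold lower number from compound 1 to compound 4 (0.21 log units; that floor lies within the scatter) is expected to be small or not readable. Compound 4 is estimated at 20000 nM, between 4000 nM and 100000 nM.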

Compound 4, concentration for total growth inhibition: 16700 nM
Compound 4: middle estimate off by 1.2-fold (0.08 log units), on the high side, and the stated range covers the measured number.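

In this assay, going by these compounds alone, compound 4 is the one compound on the core of compound 1 that returns a number rather than a limit. On the carbonyl carbon, (4-chloro-3-(trifluoromethyl)phenyl)amino in place of 4-chloro-3-(trifluoromethyl)phenyl gives an at least 1.9-fold lower number from compound 1 to compound 4 (0.28 log units; that floor lies within the scatter), so this pair does not establish a gain from the change, although it does turn a limit into a number. Among the ureas, chloro in place of hydrogen on an aromatic carbon gives an at least 2.9-fold lower number from compound 3 to compound 4 (0.47 log units; beyond the scatter), the one readable step here that clears the scatter, and it gives only a floor on the size of the chloro effect.

Going by these compounds, it remains open whether this chloro step carries over to other aryl ureas on the shared core, or whether a bromine or a methyl group in place of that chloro would give a readable number in this assay. Compound 2 differs from compound 4 in more than one place, so what separates its number from that of compound 4 stays unresolved, including the role of the second trifluoromethyl group and of the hydroxy group on its core.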